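Amide aryl change in compound 4 and cytotoxicity

This account rests on a few compounds, and the source may have more. Where it says the series, first, only, none or still open, it means among the compounds named here.

The series shares one core, seen in compound 1 `COC(=O)Nc1sc2c(c1C(=O)Nc1ccc(OC)cc1)CCCCC2`, compound 2 `O=C(Nc1ccc(Cl)cc1)c1c(NC(=O)C(F)(F)F)sc2c1CCCCC2` and compound 3 `O=C(Nc1ccc(C(F)(F)F)cc1)c1c(NC(=O)C(F)(F)F)sc2c1CCCCC2`. In an ADME assay on THP-1 cells (Homo sapiens) for cytotoxicity (on this read-out lower numbers stand for higher toxicity in this test and higher numbers for lower toxicity in this test), compound 1 gives > 50000 nM, which is a limit of the assay and not a number. In this assay compound 2 gives > 50000 nM, again only a limit. For the measured compounds named here, compound 3 is the only compound with a number: in this assay compound 3 gives 17200 nM. Going by the values given here, the one measured step is an at least 2.9-fold lower number from compound 2 to compound 3 (0.46 log units; beyond the scatter); the other two values sit at the limit of > 50000 nM in this assay, at which 2 of the 3 values shown sit.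

Compound 4 `COc1cccc(NC(=O)c2c(NC(=O)C(F)(F)F)sc3c2CCCCC3)c1` differs from compound 3 by 3-methoxyphenyl in place of 4-(trifluoromethyl)phenyl on an amide-type nitrogen. The change takes out the trifluoromethyl that, going from chloro to trifluoromethyl, lowered the number in the measured step, so the number for compound 4 is expected to rise again by a modest amount, quite possibly back to the limit. The step expected is a 2.3-fold higher number from compound 3 to compound 4 (0.37 log units; beyond the scatter). For compound 4 in this assay the estimate is 40000 nM, with a range from 15000 nM to 100000 nM.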

Compound 4, half-maximal cytotoxic concentration: 37600 nM
For compound 4 the middle estimate is 1.1-fold (0.03 log units) above the measured one, and the stated range covers the measured number.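

In this assay, for the compounds shown here, this is the first step at the amide aryl position with a number at both ends: a 2.2-fold higher number from compound 3 to compound 4 (0.34 log units; beyond the scatter). Exchanging 4-(trifluoromethyl)phenyl for 3-methoxyphenyl on an amide-type nitrogen therefore moves the read-out by a measured amount beyond the scatter, while compound 4 still gives a number and not a limit. Against the 4-chlorophenyl of compound 2, the result is an at least 1.3-fold lower number from compound 2 to compound 4 (0.12 log units; that floor lies within the scatter), and this fixes no order, since compound 2 holds only a limit: the limit of > 50000 nM in this assay, at which 2 of the 4 values shown sit.

Because 3-methoxyphenyl and 4-(trifluoromethyl)phenyl differ in both the group and the name of its ring position, the compounds shown do not separate these two changes: the limit of > 50000 nM in this assay, at which 2 of the 4 values shown sit. As far as these compounds go, how an amine or a carboxylic acid on the same aryl ring would read in this assay remains open.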